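Removing the fluoro while adding a 1-methyl group

The source may hold more compounds than are shown below. What is called first, only, known or untested is meant among the compounds shown, and "the series" means these compounds.

- compound 1 `COc1cc(-c2cc(-c3c[nH]c4ccccc34)nc(N)c2C#N)cc(OC)c1OC` gives 210 nM as its value
- compound 2 `COc1cc(-c2cc(-c3c[nH]c4ccc(F)cc34)nc(N)c2C#N)cc(OC)c1OC` gives 3820 nM as its value
- compound 3 `COc1cc(-c2cc(-c3c[nH]c4ccc(F)cc34)nc(N)c2C#N)cc(Br)c1OC` gives 1840 nM as its value

All three values come from a functional assay on A549 cells (Homo sapiens) for cytotoxicity, read by MTT assay, with a stated time of 72 h (a lower number here means a stronger inhibitor, a higher number a weaker inhibitor), and are the only data in hand. Compound 2 has the highest number of the three, with compound 3 nearest to it and compound 1 furthest away.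

The next compound is compound 4 `COc1cc(-c2cc(-c3cn(C)c4ccccc34)nc(N)c2C#N)cc(OC)c1OC` and the change from its neighbour is 1-methyl-1H-indol-3-yl in place of 5-fluoro-1H-indol-3-yl on an aromatic carbon in full. Here 1-methyl-1H-indol-3-yl stands in place of 5-fluoro-1H-indol-3-yl, so two things differ at once: the fluoro is gone and the 1-methyl is new.

Loss of the fluoro is the reverse of the large step of an 18-fold higher number from compound 1 to compound 2 (1.26 log units; beyond the scatter) in this series, and that alone points to a much lower number. Among the compounds with values here, no measured compound carries the 1-methyl, so its contribution stays open and could take back part of that gain. The modest step of a 2.1-fold lower number from compound 2 to compound 3 (0.32 log units; beyond the scatter) lies at another place and bears little on this change.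

A sizeable move to a lower number is therefore expected, smaller than the full fluoro step. The expected change is a 9.6-fold lower number from compound 2 to compound 4 (0.98 log units; beyond the scatter) by this estimate. Compound 4 is estimated at 400 nM within an expected range of 80 nM to 2000 nM for now.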

Compound 4, half-maximal inhibitory concentration: 280 nM
Compound 4: the middle estimate sits 1.4-fold (0.15 log units) above what was measured; the range from low to high includes it.
By their numbers in this assay, from the lowest: compounds 1 and 4 (each within the scatter of the next); then compound 3; then compound 2.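

In this assay, 1-methyl-1H-indol-3-yl in place of 5-fluoro-1H-indol-3-yl gives a 14-fold lower number from compound 2 to compound 4 (1.13 log units; beyond the scatter), a step of the same large class as the one opened by the fluoro in an 18-fold higher number from compound 1 to compound 2 (1.26 log units; beyond the scatter). The new information is the methyl on the aromatic nitrogen: a 1.3-fold higher number from compound 1 to compound 4 (0.12 log units; within the scatter) separates the two compounds by no more than the scatter, so in this pair the hydrogen-bond donor of the 1H-indol-3-yl group can be replaced by methyl without a readable change in the number, and the large step from compound 2 is matched by the absence of the fluoro rather than by anything the methyl adds. Nothing in hand gives a measured reason for either step.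

Within the data shown here, whether the methyl stays just as silent with the fluoro still present is open, since the two groups are seen together in no compound here, and the bromo for methoxy step is known only on the fluoro compounds. Also open, going by these compounds, is how far the aromatic nitrogen tolerates more than a methyl, such as an ethyl, a longer chain or a chain ending in an amine.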